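Oxygen substituent step from compound 3 to compound 4

This account rests on a few compounds, and the source may have more. Where it says the series, first, only, none or still open, it means among the compounds named here.

In a functional assay on RAW264.7 cells (Mus musculus) for inhibition, read by ELISA, with a stated time of 24 h (on this read-out lower numbers stand for an effect already at smaller amounts and higher numbers for an effect only at larger amounts of compound), compound 3 `CC/C=C\C[C@H]1C(=O)C=C[C@H]1CC(=O)OCc1ccccc1` gives 20000 nM, level with compound 1 `CC/C=C\C[C@H]1C(=O)C=C[C@H]1CC(=O)OCC` at 20000 nM. Compound 2 `CC/C=C\C[C@H]1C(=O)C=C[C@H]1CC(=O)Oc1ccccc1` gives 33000 nM, within the scatter of both. Compound 4 `CC/C=C\C[C@H]1C(=O)C=C[C@H]1CC(=O)Oc1ccc(O)cc1` is unmeasured and carries 4-hydroxyphenyl in place of benzyl on an oxygen next to a carbonyl group.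

Three measured steps change this same substituent: a 1.7-fold higher number from compound 1 to compound 2 (0.22 log units; within the scatter), a 1.7-fold lower number from compound 2 to compound 3 (0.22 log units; within the scatter) and no change at the digits printed from compound 1 to compound 3 (within the scatter). For the measured compounds named here, all lie within the scatter, although no measured compound tests the hydroxy group itself. The expected step in this assay is therefore small, a 1.3-fold higher number from compound 3 to compound 4 (0.10 log units; within the scatter), and none beyond the scatter. Compound 4 is estimated at 25000 nM, with an expected range of 10000 nM to 55000 nM.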

Compound 4, half-maximal effective concentration: 23000 nM
Compound 4: the middle estimate sits 1.1-fold (0.04 log units) above what was measured; low and high end bracket the measured number.
By their numbers in this assay, from the lowest: compounds 1, 3, 4 and 2 (each within the scatter of the next).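

In this assay, for the compounds shown here, hydroxy in place of hydrogen on an aromatic carbon, a change no earlier pair tests, gives a 1.4-fold lower number from compound 2 to compound 4 (0.16 log units; within the scatter) and so stays within the scatter. All four groups on this oxygen now lie within the scatter of one another: 4-hydroxyphenyl in place of benzyl gives a 1.2-fold higher number from compound 3 to compound 4 (0.06 log units; within the scatter) and 4-hydroxyphenyl in place of ethyl gives a 1.2-fold higher number from compound 1 to compound 4 (0.06 log units; within the scatter) on the same read-out. Nothing available explains this narrow spread.

From the compounds shown here alone, whether an amine or a carboxylic acid on the phenyl ring, or a longer chain on this oxygen, moves the number beyond the scatter remains open. Going by these compounds, the effect of changes to the shared core also remains open.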